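This account rests on a few compounds, and the source may have more. Where it says the series, first, only, none or still open, it means among the compounds named here.

Compound 1, with the structure `c1ccc2c(-c3cn4ccnc4c(-c4ccc5ncn(C6CCCCC6)c5c4)n3)cccc2c1`, gives 2.3% in a functional assay on SK-MEL-2 cells (Homo sapiens) for inhibition, read by sulforhodamine B assay, with a stated time of 48 h, tested at 10 uM; on this read-out higher numbers stand for more inhibition at the one concentration tested (going by the name of the read-out) and lower numbers for less inhibition. Compound 2, with the structure `c1ccc(Cn2cnc3ccc(-c4nc(-c5cccc6ccccc56)cn5ccnc45)cc32)cc1`, gives 17% in this assay. The two differ by one change, (benzyl in place of cyclohexyl on an aromatic nitrogen), and that change made a step of a number 14.7 percentage points higher from compound 1 to compound 2 (beyond the scatter).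

Compound 3, with the structure `c1cn2cc(-c3ccc4c(c3)ncn4C3CCCCC3)nc(-c3ccc4ncn(C5CCCCC5)c4c3)c2n1`, gives 13.7% in this assay. Its core and the core of compound 1 differ in more than one place, and the difference between the two cores is not broken down here.

Compound 4, with the structure `c1ccc(Cn2cnc3ccc(-c4nc(-c5ccc6c(c5)ncn6C5CCCCC5)cn5ccnc45)cc32)cc1`, is not yet measured. Among the compounds with values here, it arises from compound 3 by benzyl in place of cyclohexyl on an aromatic nitrogen, which is the same change as the one from compound 1 to compound 2, made at the same kind of place.

Within the data shown here, the step expected from compound 3 to compound 4 is a number 11.3 percentage points higher from compound 3 to compound 4 (beyond the scatter), and this expectation rests on the single earlier step of a number 14.7 percentage points higher from compound 1 to compound 2 (beyond the scatter). One pair alone cannot show how far the change carries over, and the expectation is held with caution. Compound 4 is therefore expected to give about 25%, estimated to lie between 8% and 42%.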

Compound 4, a percentage reported as inhibition, at one concentration (the size of the read-out at that concentration, not a potency): -36.7%
Compound 4: the middle estimate sits 61.7 percentage points above what was measured, and the stated range ends above it.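

Benzyl in place of cyclohexyl on an aromatic nitrogen gave a number 50.4 percentage points lower from compound 3 to compound 4 (beyond the scatter) in this assay, so the earlier step did not carry over from the core of compound 1 to the core of compound 3. Set side by side, the two steps run in opposite directions: the same change on two cores in this assay, a number 14.7 percentage points higher (beyond the scatter) from compound 1 to compound 2 and a number 50.4 percentage points lower (beyond the scatter) from compound 3 to compound 4, 65.1 percentage points apart, beyond the scatter of two such steps

This shows that in these four compounds the outcome of the change depends on the core that carries it, so a step seen on one core is a poor guide to the step on the other; it does not show which feature of the cores decides the outcome, and two pairs cannot tell which direction would be more usual in the wider series.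

The compounds shown leave open how other groups on that aromatic nitrogen would behave on these two cores, such as a methyl, a longer carbon chain or a chain ending in an amine. They also leave open which way the same change would go on a third core.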